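This account rests on a few compounds, and the source may have more. Where it says the series, first, only, none or still open, it means among the compounds named here.

Compound 2 `COC(=O)C1=C(C)N=C(C)/C(=C(\O)OC)C1c1cccc(N)c1` stands second highest of the three numbers in a functional assay (muscle tissue) with Cavia porcellus as the target (a higher number here means that more compound is needed for the effect, a lower number that less compound is needed), giving 2000 nM. For the measured compounds named here, compound 1 `COC(=O)C1=C(C)N=C(C)/C(=C(\O)OC)C1c1cccc(OC(C)=O)c1` gives 6030 nM, and the step of a 3.0-fold lower number from compound 1 to compound 2 (0.48 log units; beyond the scatter) is the only single-place step among the measured compounds. Compound 3 `COC(=O)C1=C(C)N=C(C)/C(=C(/O)OC)C1c1cccc(Cl)c1` gives 15.9 nM, a number far below that of compound 2. Compound 4 `COC(=O)C1=C(C)N=C(C)/C(=C(\O)OC)C1c1ccccc1Br` has not yet been measured; it differs from compound 2 by 2-bromophenyl in place of 3-aminophenyl on a saturated ring carbon. Going by the values given here, no measured step covers this change directly: the step from compound 1 to compound 2 exchanges one group on the aromatic ring for another, whereas here the whole aryl group is replaced, so that step bears on it only loosely. What the values of compound 2 and compound 3 show is that a different aryl group can move the number a long way downward. On that basis a lower number is expected for compound 4, though with wide uncertainty. The expected step is a 33-fold lower number from compound 2 to compound 4 (1.52 log units; beyond the scatter). The estimate for compound 4 is 60 nM, within a range from 10 nM to 400 nM.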

Compound 4, half-maximal effective concentration: 7.59 nM
Beside the measured number, compound 4's estimate is 7.9-fold (0.90 log units) above it; measured number below the stated range.
By their numbers in this assay, from the lowest: compound 4; then compound 3; then compound 2; then compound 1.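

Replacing 3-aminophenyl with 2-bromophenyl on the saturated ring carbon gives a 260-fold lower number from compound 2 to compound 4 (2.42 log units; beyond the scatter) in this assay. For the compounds shown here, this is a much larger move than a 3.0-fold lower number from compound 1 to compound 2 (0.48 log units; beyond the scatter), the only earlier step, which exchanged one group on the aromatic ring for another. The result shows that a single exchange of the whole aryl group at this position can move the number a long way, but the change alters both the substituent and its place on the ring, so the step cannot be divided between them. Nothing available explains the size of this step. The compounds shown leave open whether the bromine or its place on the ring matters more, which 3-bromophenyl and 2-aminophenyl would separate, and how a phenyl without any substituent would compare.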